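Methoxy to Hydroxy: One Change, One Cell Assay

The compounds below may be only part of what the source reports. "The series", "measured", "known", "first", "only" and "open" are said of these compounds alone.

Two compounds share one core. Compound 1 `COc1cc(Cl)cc(-c2nn(-c3cccc(NC(=O)Nc4cccc(C(F)(F)F)c4)c3)cc2-c2ccncc2)c1` carries a methoxy group; compound 2 `COc1cc(Cl)cc(-c2nn(-c3cccc(NC(=O)Nc4ccc(Cl)c(C(F)(F)F)c4)c3)cc2-c2ccncc2)c1` differs from it by a chloro in place of hydrogen on an aromatic carbon. In a functional assay on NCI-H226 cells (Homo sapiens) for inhibition, read by sulforhodamine B assay, with a stated time of 48 h, tested at 10 uM (a lower number here means a stronger effect, a higher number a weaker effect of the compound at the concentration tested), compound 1 gives 3.94%, and compound 2 gives -2.82%. The change a number 6.8 percentage points lower from compound 1 to compound 2 (within the scatter) sits within the scatter, so the two compounds cannot be told apart, and compound 2 stands at a number that points to little effect at the tested concentration. Compound 3 `O=C(Nc1cccc(-n2cc(-c3ccncc3)c(-c3cc(O)cc(Cl)c3)n2)c1)Nc1ccc(Cl)c(C(F)(F)F)c1` is the next step: hydrogen in place of methyl on an oxygen on an aromatic ring, the methoxy becoming a hydroxy. Going by the values given here, no measured step touches this oxygen, so the only footing is the pair already seen, both near zero. The expectation for compound 3 is therefore a number 2.8 percentage points higher from compound 2 to compound 3 (within the scatter), a step not beyond the scatter. Compound 3 is estimated at 0%, between -12% and 12%.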

Compound 3, a percentage reported as activity, at one concentration (the size of the read-out at that concentration, not a potency): 41.2%
The estimate for compound 3 lay 41.2 percentage points below the measured number; the whole stated range lies below it.
By their numbers in this assay, from the lowest: compounds 2 and 1 (each within the scatter of the next); then compound 3.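

In this assay, removing a single methyl from the oxygen gives a number 44 percentage points higher from compound 2 to compound 3 (beyond the scatter), so this position responds to a small change in a way the chloro step did not, since that step reads a number 6.8 percentage points lower from compound 1 to compound 2 (within the scatter). In this read-out a higher number means a weaker effect, so among this pair the weaker effect goes with the hydroxy of compound 3, and the stronger effect with the methoxy of compound 2. No measurement shown here explains why the number moves so far with this one change.

The compounds shown leave open whether a longer chain on this oxygen, such as ethoxy, would behave like the methoxy of compound 2, or whether an amine in place of the hydroxy would behave like compound 3. They also leave open whether methoxy to hydroxy would give a step of similar size starting from compound 1.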